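A few compounds are considered here, and "the series" means these few. Any claim that something is new, unique, unknown or untested is made for them only; others in the source may bear on it.

Measured compounds, with their values in a physicochemical assay for lipophilicity, read by HPLC, at pH 7.5; a lower number here means a more polar compound, a higher number a more lipophilic compound:

compound 1 `CCCCC(Nc1c(C#N)c(-c2ccc(-c3ccccc3OCC)cc2)nc2cnccc12)C(N)=O`: 3.6
compound 2 `CN(CC(N)=O)c1c(C#N)c(-c2ccc(Br)cc2)nc2cnccc12`: 2.1
compound 3 `CC[C@@H](Nc1c(C#N)c(-c2ccc(-c3cnccc3C)cc2)nc2cnccc12)C(N)=O`: 2

Among these three, compound 1 has the highest number. Compound 2 comes nearest to it, and that gap is already beyond the usual scatter of repeated measurements; compound 3 lies furthest away, also beyond the scatter. For the measured compounds named here, no two of the measured compounds differ from each other in only one place, so no single structural step has been measured directly, and the effect of the change below has to be judged from the structures alone.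

Compound 4 `CCOc1ccccc1-c1ccc(-c2nc3cnccc3c(C[C@H](C)C(N)=O)c2C#N)cc1` has not yet been measured. Going by the values given here, it differs from compound 1 in one place: a group of 6 heavy atoms (4 carbon, 1 nitrogen, 1 oxygen; no ring) in place of a group of 9 heavy atoms (6 carbon, 2 nitrogen, 1 oxygen; no ring), on an aromatic carbon A smaller group thus takes the place of a larger one on the shared core, and the group that leaves carried the only hydrogen-bond donor pair among the two.

Among the compounds with values here, with no measured step to lean on, the step from compound 1 to compound 4 is expected to go downwards, most likely by more than the scatter, at a number 0.70 log units lower from compound 1 to compound 4 (beyond the scatter). Compound 4 is therefore estimated to give about 2.9 in this assay, with a likely range from 2.3 to 3.5.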

Compound 4, distribution coefficient: 3
Estimate against measurement, compound 4: 0.10 log units below, and the stated range covers the measured number.
By their numbers in this assay, from the lowest: compounds 3 and 2 (each within the scatter of the next); then compound 4; then compound 1.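

In this assay, for the compounds shown here, replacing the larger open-chain group with 2-carbamoylpropyl gives a number 0.60 log units lower from compound 1 to compound 4 (beyond the scatter), the first directly measured step at this aromatic carbon, ortho to a cyano group. With the rest of the molecule unchanged, the reading therefore responds to the group placed here, even though the group that enters has fewer hydrogen-bond donors than the group that leaves. Nothing at hand explains why the number moves in this direction.

Size and hydrogen-bond donor count change together in this single step, so their separate contributions cannot be told apart. On these data alone, it also remains open whether a simple amine or a carboxylic acid on this carbon would move the number the same way, and what part the defined stereocentre of 2-carbamoylpropyl plays.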